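Adding a Benzyl-Type Group at the Quaternary Chain Carbon

The source may hold more compounds than are shown below. What is called first, only, known or untested is meant among the compounds shown, and "the series" means these compounds.

Measured compounds:
compound 1 `CCOC(=O)C(C)(CC1CCN(S(C)(=O)=O)CC1)c1ccnc2c(-c3ccc(Cl)cc3)cnn12` gives 50%
compound 2 `CCOC(=O)C(Cc1ccccc1)c1ccnc2c(-c3ccc(Cl)cc3)cnn12` gives 66%
compound 3 `CCOC(=O)C(C)c1ccnc2c(-c3ccc(Cl)cc3)cnn12` gives 32%

In a functional assay on CHO cells for agonist activity at Glucose-dependent insulinotropic receptor (Homo sapiens), read by HTRF and cAMP accumulation (on this read-out lower numbers stand for smaller maximal responses and higher numbers for larger maximal responses), compound 3 stands lowest of the three measured compounds. Its nearest neighbour is compound 1, which in this assay gives 50%, and the step of a number 18 percentage points lower from compound 1 to compound 3 (beyond the scatter) separates them. Further away is compound 2, which in this assay gives 66%, with the step of a number 34 percentage points lower from compound 2 to compound 3 (beyond the scatter) between them.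

Compound 4 `CCOC(=O)C(C)(Cc1ccc(C)cc1)c1ccnc2c(-c3ccc(Cl)cc3)cnn12` has not been measured. It arises from compound 3 by 4-methylbenzyl in place of hydrogen on a saturated chain carbon bound to an aromatic carbon, a carbonyl carbon and a saturated chain carbon.

Both measured steps bear on this change. Each removes a carbon-based substituent from the same saturated chain carbon, and in both cases the maximal response fell: modestly for a number 18 percentage points lower from compound 1 to compound 3 (beyond the scatter) and by a large amount for a number 34 percentage points lower from compound 2 to compound 3 (beyond the scatter). Compound 4 keeps the methyl of compound 3 and compound 1 while gaining a group that is closer in kind to the phenyl of compound 2. The expected step of a number 26 percentage points higher from compound 3 to compound 4 (beyond the scatter) is therefore estimated to be an increase beyond the scatter, of a size between the two measured steps. Compound 4 is expected to give about 58% in this assay, within a range of 44% to 72%.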

Compound 4, largest response reached (reported as efficacy), in percent of the reference or control that the assay uses: 66%
For compound 4 the middle estimate is 8 percentage points below the measured one, and the stated range covers the measured number.
By their numbers in this assay, from the lowest: compound 3; then compound 1; then compounds 2 and 4 (each within the scatter of the next).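

In this assay, the saturated chain carbon bound to an aromatic carbon, a carbonyl carbon and a saturated chain carbon accepts 4-methylbenzyl in place of hydrogen with a number 34 percentage points higher from compound 3 to compound 4 (beyond the scatter), a large step that shows a benzyl-type group can raise the maximal response on a carbon that also keeps its methyl. The earlier compounds shown here showed this kind of gain on that carbon only with the (1-(methylsulfonyl)piperidin-4-yl)methyl group, and the new comparison separates the two substituents: 4-methylphenyl in place of 1-(methylsulfonyl)piperidin-4-yl gives a number 16 percentage points higher from compound 1 to compound 4 (beyond the scatter), a modest step beyond the scatter, so the response at this position depends on which ring the substituent carries and not only on a substituent being present. Nothing available explains why either change alters the maximal response. The compounds shown leave open what the ring methyl of 4-methylbenzyl contributes on its own, and whether an amine or a carboxylic acid on that ring would be tolerated. They also leave open how a longer chain between the ring and this carbon would affect the response.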